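Opening the Cyclopropyl Ring on an Amide Side Chain

The source may report more compounds than this note shows. Statements on the series, on what has been measured and on what is new or still open speak of the compounds shown alone.

Of the compounds shown here, two sharing one core have been measured so far. In a functional assay on MCF7 cells (Homo sapiens) for antiproliferative activity, read by MTT assay, with a stated time of 24 h (on this read-out lower numbers stand for stronger inhibition and higher numbers for weaker inhibition), compound 1 (`CCn1c(C(=O)N[C@@H](C)C(=O)OC)ccc1C(CC)(CC)c1ccc(OCS(=O)(=O)c2ccccc2)c(C)c1`) gives 43700 nM and compound 2 (`CCn1c(C(=O)NC2(CO)CC2)ccc1C(CC)(CC)c1ccc(OCS(=O)(=O)c2ccccc2)c(C)c1`) gives 28800 nM on the same scale. These two numbers cannot be ranked, so compound 2 stands level with compound 1 at the weak end of what a potent inhibitor would show.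

Compound 3 (`CCn1c(C(=O)N[C@@H](CO)CCO)ccc1C(CC)(CC)c1ccc(OCS(=O)(=O)c2ccccc2)c(C)c1`) keeps the core and alters only the group on the amide-type nitrogen, where 3-hydroxy-1-(hydroxymethyl)propyl in place of 1-(hydroxymethyl)cyclopropyl on an amide-type nitrogen is the full difference. The three-membered ring leaves, and the entering 3-hydroxy-1-(hydroxymethyl)propyl has no ring.

Going by the values given here, one measured step bears on this, since it concerns the same nitrogen: a 1.5-fold lower number from compound 1 to compound 2 (0.18 log units; within the scatter) is all the evidence there is. Among the compounds with values here, no compound with an open chain carrying two hydroxyl groups has been measured, so that single step is a thin guide. On that basis no step beyond the scatter is expected in this assay for this swap. The estimated step is a 1.0-fold higher number from compound 2 to compound 3 (0.02 log units; within the scatter) and it would mean no real difference. For compound 3 the estimated value is 30000 nM with an expected range of 14000 nM to 65000 nM on repeat measurement.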

Compound 3, half-maximal inhibitory concentration: 27400 nM
Beside the measured number, compound 3's estimate is 1.1-fold (0.04 log units) above it; the range from low to high includes it.
By their numbers in this assay, from the lowest: compounds 3, 2 and 1 (each within the scatter of the next).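

In this assay, the open 3-hydroxy-1-(hydroxymethyl)propyl chain takes the place of the 1-(hydroxymethyl)cyclopropyl ring on the amide-type nitrogen (a 1.1-fold lower number from compound 2 to compound 3 (0.02 log units; within the scatter)), so removing the three-membered ring produces no real difference here. The comparison with the 1-(methoxycarbonyl)ethyl group of compound 1 reads the same way (a 1.6-fold lower number from compound 1 to compound 3 (0.20 log units; within the scatter)), which means that three differently built groups on this nitrogen, one with a ring, one with an ester and one with an open chain carrying two hydroxyl groups, now all lie within the scatter of one another. Nothing available here explains why these groups give such similar numbers.

Going by these compounds, whether an amine, a carboxylic acid or a longer chain on this nitrogen would give a step beyond the scatter remains open, since all three groups seen so far leave the compounds at a similarly weak level. Also open, on these data alone, is whether a change elsewhere on the shared core would matter more than any change at this nitrogen, as all three compounds carry that core unchanged.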